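Swapping the amide tail: aryl out, amine chain in

The source may hold more compounds than are shown below. What is called first, only, known or untested is meant among the compounds shown, and "the series" means these compounds.

Measured so far:
- compound 1, `O=C(CCC(=O)OCCCCCCSc1ccc([N+](=O)[O-])c2nonc12)Nc1ccccc1`, 700 nM
- compound 2, `O=C(CCC(=O)OCCCCCCSc1ccc([N+](=O)[O-])c2nonc12)Nc1ccc(F)c(Cl)c1`, 470 nM

Both compounds were tested in an assay on isolated protein for inhibition of glutathione S-transferase Mu 2 (Homo sapiens), with a stated time of 10 min; a lower number here means a stronger inhibitor, a higher number a weaker inhibitor. Going by the values given here, compound 2 gives the lowest of the two numbers, with compound 1 its only neighbour; the step of a 1.5-fold lower number from compound 1 to compound 2 (0.17 log units; within the scatter) is the only one recorded, and it stays within the scatter, so the two compounds cannot be told apart by strength.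

Compound 3, `CCN(CC)CCCNC(=O)CCC(=O)OCCCCCCSc1ccc([N+](=O)[O-])c2nonc12`, has not been tested. Its change from compound 2 is 3-(diethylamino)propyl in place of 3-chloro-4-fluorophenyl on an amide-type nitrogen. Among the compounds with values here, no measured step touches this kind of swap: the one recorded step only exchanged one aromatic ring for another at the same nitrogen and did not move the number beyond the scatter. The shared core is kept, so the expectation for compound 3 in this assay is a number close to that of compound 2, with a wide margin in both directions, a step of a 1.7-fold higher number from compound 2 to compound 3 (0.23 log units; within the scatter). The estimate for compound 3 is 800 nM, between 250 nM and 2500 nM.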

Compound 3, half-maximal inhibitory concentration: 440 nM
Beside the measured number, compound 3's estimate is 1.8-fold (0.26 log units) above it; the measured number falls inside the stated range.
By their numbers in this assay, from the lowest: compounds 3, 2 and 1 (each within the scatter of the next).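

In this assay, the aromatic ring on the amide-type nitrogen can be replaced by 3-(diethylamino)propyl, a chain with no ring, and the readings stay together: the data show a 1.1-fold lower number from compound 2 to compound 3 (0.03 log units; within the scatter) and a 1.6-fold lower number from compound 1 to compound 3 (0.20 log units; within the scatter). Until now, this position had only shown one aromatic ring exchanged for another, so this is the first sign that neither a ring nor the chlorine and fluorine atoms are needed to keep the number at this level. Nothing available explains why the number stays put.

From the compounds shown here alone, whether this holds for any group at this nitrogen remains open, for example a carboxylic acid, a morpholine or a much longer chain. The three compounds also cannot show whether removing the amide hydrogen, by adding a second group to that nitrogen, would move the number.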